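Adding a Piperidin-1-ylmethyl Group to Compound 1

The compounds below may be only part of what the source reports. "The series", "measured", "known", "first", "only" and "open" are said of these compounds alone.

Compound 1 `COc1cc(O)c(C(=O)c2ccccc2F)c(OC)c1` gives 71% in a functional assay on THP-1 cells (Homo sapiens) for inhibition, read by ELISA, with stated times of 30 min and 24 h, tested at 10 uM (on this read-out higher numbers stand for a stronger effect at the one concentration tested and lower numbers for a weaker effect), the lowest of the three numbers measured. Compound 2 `COc1cc(O)c(C(=O)c2ccccc2Br)c(OC)c1`, with bromo in place of fluoro on an aromatic carbon, gives 72%; the step of a number 1 percentage points higher from compound 1 to compound 2 (within the scatter) is flat. Compound 3 `COc1cc(OC)c(C(=O)c2cccc(F)c2)c(O)c1CN1CCCC1` gives 93%, beyond the scatter above compound 1, but it differs from compound 1 in more than one place. Compound 4 `COc1cc(OC)c(C(=O)c2ccccc2F)c(O)c1CN1CCCCC1` differs from compound 1 by (piperidin-1-yl)methyl in place of hydrogen on an aromatic carbon. Within the data shown here, no measured step matches this change exactly; the halogen swap changed nothing, while compound 3, the only measured compound of comparable build, reads 93%. An upward step is therefore expected, a number 16 percentage points higher from compound 1 to compound 4 (beyond the scatter). Compound 4 is estimated at 87%, with a range from 74% to 97%.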

Compound 4, a percentage reported as activity, at one concentration (the size of the read-out at that concentration, not a potency): 84%
The estimate for compound 4 lay 3 percentage points above the measured number, and the stated range covers the measured number.
By their numbers in this assay, from the lowest: compounds 1 and 2 (each within the scatter of the next); then compounds 4 and 3 (each within the scatter of the next).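

Putting (piperidin-1-yl)methyl in place of hydrogen on this aromatic carbon, ortho to a hydroxy group, gives a number 13 percentage points higher from compound 1 to compound 4 (beyond the scatter). This is the first single change shown here to lie beyond the scatter, whereas a number 1 percentage points higher from compound 1 to compound 2 (within the scatter) does not. No experimental evidence is available to explain the step.

The compounds shown leave open whether the nitrogen of this group matters, or only the added ring. A plain methyl or an open-chain dimethylaminomethyl group on the same carbon would help to separate these possibilities.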